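The source may hold more compounds than are shown below. What is called first, only, known or untested is meant among the compounds shown, and "the series" means these compounds.

Of the compounds shown here, three have been measured in an ADME assay on the whole organism for pharmacokinetics, with Homo sapiens as the target; a higher number here means that a larger share of the oral dose reaches the circulation, a lower number that a smaller share of the oral dose reaches the circulation. Compound 1 `O=[N+]([O-])c1cccc(NS(=O)(=O)c2ccc3nc(-c4ccccc4)c(-c4ccccc4)nc3c2)c1` gives 85.6%. Compound 2 `O=S(=O)(Nc1cccc2ccccc12)c1ccc2nc(-c3ccccc3)c(-c3ccccc3)nc2c1` gives 100%. Compound 3 `O=S(=O)(Nc1ccccc1)c1ccc2nc(-c3ccccc3)c(-c3ccccc3)nc2c1` gives 100%.

Compound 1 stands lowest of the three: the steps of a number 14.4 percentage points higher from compound 1 to compound 2 (beyond the scatter) and a number 14.4 percentage points higher from compound 1 to compound 3 (beyond the scatter) both lie beyond the scatter, while no change at the digits printed from compound 2 to compound 3 (within the scatter). The unmeasured compound 4 `O=C(NS(=O)(=O)c1ccc2nc(-c3ccccc3)c(-c3ccccc3)nc2c1)c1ccccc1` differs from compound 1 in one place: benzoyl in place of 3-nitrophenyl on a sulfonamide nitrogen. Both measured steps away from compound 1 also remove the 3-nitrophenyl group, or the nitro on it, from the sulfonamide nitrogen, and both raised the share reaching the circulation by a modest amount. Within the data shown here, no measured step introduces a benzoyl group, so the comparison rests on the removal alone. A modest rise is therefore expected for compound 4 in this assay , with a ceiling that compound 2 and compound 3 already touch, so the step is expected to be a number 9.4 percentage points higher from compound 1 to compound 4 (within the scatter). The estimate for compound 4 is 95%, with a range from 75% to 100%.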

Compound 4, oral bioavailability: 100%
Estimate against measurement, compound 4: 5 percentage points below; the measured number falls inside the stated range.
By their numbers in this assay, from the lowest: compound 1; then compounds 2, 3 and 4 (each within the scatter of the next).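

In this assay, swapping 3-nitrophenyl for benzoyl on the sulfonamide nitrogen gives a number 14.4 percentage points higher from compound 1 to compound 4 (beyond the scatter), and against the two other replacements there is no change at the digits printed from compound 3 to compound 4 (within the scatter) and no change at the digits printed from compound 2 to compound 4 (within the scatter). So this position does not need an aryl group on the nitrogen to reach the level of compound 2 and compound 3: a carbonyl-linked benzoyl group does the same, and among these four only compound 1, with its 3-nitrophenyl, stands apart. No measurement here explains why these groups behave alike.

With compound 4 at 100%, the whole dose, any real differences among compound 2, compound 3 and compound 4 cannot show in these numbers. From the compounds shown here alone, whether the number holds with a group that has no aromatic ring, such as acetyl or a short alkyl chain, or with an amine or a carboxylic acid in place of the nitro group, remains open.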